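The source may hold more compounds than are shown below. What is called first, only, known or untested is meant among the compounds shown, and "the series" means these compounds.

In a functional assay, read by spectrophotometry (a higher number here means that more compound is needed for the effect, a lower number that less compound is needed), compound 1 `COc1ccc(-c2cc(=O)c3ccc(O)cc3o2)cc1OC` gives 22.4 nM. Compound 2 `COc1ccc(-c2cc(=O)c3ccc(OCCCN4CCC(CCO)CC4)cc3o2)cc1` gives 22.8 nM, and compound 3 `COc1ccc(-c2cc(=O)c3ccc(OCCCCN4CCC(CCO)CC4)cc3o2)cc1` gives 23.2 nM. These three numbers lie within the scatter of one another, so compound 3 stands level with both of the other compounds.

Compound 4 `COc1ccc(-c2cc(=O)c3ccc(OCCCCCN4CCC(CCO)CC4)cc3o2)cc1` differs from compound 3 in one place: (4-(2-hydroxyethyl)piperidin-1-yl)methyl replaces 4-(2-hydroxyethyl)piperidin-1-yl on a saturated chain carbon, four bonds along the chain from an oxygen on an aromatic ring. The full count of that difference is (4-(2-hydroxyethyl)piperidin-1-yl)methyl in place of 4-(2-hydroxyethyl)piperidin-1-yl on a saturated chain carbon, four bonds along the chain from an oxygen on an aromatic ring.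

Within the data shown here, one measured step bears on this change, the same exchange made three bonds along the chain from that oxygen. It came to a 1.0-fold higher number from compound 2 to compound 3 (0.01 log units; within the scatter). This is a single step, so it is thin evidence, but it gives no reason to expect a move beyond the scatter in this assay in either direction. The estimated step is a 1.0-fold lower number from compound 3 to compound 4 (0.00 log units; within the scatter). Compound 4 is expected at about 23 nM, with an estimated range from 12 nM to 45 nM.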

Compound 4, half-maximal effective concentration: 27.9 nM
The estimate for compound 4 lay 1.2-fold (0.08 log units) below the measured number; the measured number falls inside the stated range.
By their numbers in this assay, from the lowest: compounds 1, 2, 3 and 4 (each within the scatter of the next).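

In this assay, placing (4-(2-hydroxyethyl)piperidin-1-yl)methyl in place of 4-(2-hydroxyethyl)piperidin-1-yl four bonds along the chain from the oxygen on the aromatic ring gives a 1.2-fold higher number from compound 3 to compound 4 (0.08 log units; within the scatter). The same exchange has now stayed within the scatter at a second place along the chain, and the widest difference in chain length among these compounds also stays within it, with a 1.2-fold higher number from compound 2 to compound 4 (0.09 log units; within the scatter). No measurement available here offers an explanation for this flat result.

Going by these compounds, whether a still longer chain would remain level with these compounds stays open. So does the outcome of replacing the 4-(2-hydroxyethyl)piperidin-1-yl group at the chain end with another group, such as a morpholine or a carboxylic acid.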